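Swapping bromine for iodine on a hydroxyphenyl thioenone

The source may hold more compounds than are shown below. What is called first, only, known or untested is meant among the compounds shown, and "the series" means these compounds.

The measured compounds are:
compound 1 `Cc1ccsc1/C=C(/SCc1ccc(Cl)cc1)C(=O)c1ccc(Cl)cc1` with 50000 nM in a functional assay on DU-145 cells (Homo sapiens) for inhibition, read by trypan blue exclusion, with a stated time of 96 h; on this read-out higher numbers stand for weaker inhibition of growth and lower numbers for stronger inhibition of growth;
compound 2 `O=C(/C(=C\c1cc(Br)c(O)c(Br)c1)SCc1ccc(Br)cc1)c1ccc(Br)cc1` with 1000 nM in this assay;
compound 3 `Cc1ccc(S/C(=C/c2cc([N+](=O)[O-])ccc2F)C(=O)c2ccc(Cl)cc2)cc1` with 10000 nM in this assay.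

Among these three, compound 2 stands lowest in this assay. Its nearest neighbour is compound 3, whose number is higher by a gap beyond the scatter, and compound 1 lies furthest away, higher still. For the measured compounds named here, no two of the measured compounds differ in only one place, so no single step between them can be drawn from these numbers.

Compound 4 `O=C(/C(=C\c1cc(I)c(O)c(I)c1)SCc1ccc(Br)cc1)c1ccc(Br)cc1` has not yet been measured. It differs from compound 2 in one place: 4-hydroxy-3,5-diiodophenyl in place of 3,5-dibromo-4-hydroxyphenyl on a double-bonded chain carbon bound to a double-bonded chain carbon. The change keeps the count of heavy atoms, donors and acceptors unchanged, replacing one halogen pair by another. Going by the values given here, with no measured halogen-for-halogen step to lean on, the step of a 1.3-fold lower number from compound 2 to compound 4 (0.10 log units; within the scatter) is expected to fall within the usual scatter, with no clear direction. Compound 4 is therefore estimated at 800 nM, in a range from 250 nM to 3000 nM.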

Compound 4, concentration for 50% growth inhibition: 1000 nM
Compound 4: the middle estimate sits 1.3-fold (0.10 log units) below what was measured; the measured number falls inside the stated range.
By their numbers in this assay, from the lowest: compounds 2 and 4 (each within the scatter of the next); then compound 3; then compound 1.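

In this assay, for the compounds shown here, putting 4-hydroxy-3,5-diiodophenyl in place of 3,5-dibromo-4-hydroxyphenyl on a double-bonded chain carbon bound to a double-bonded chain carbon gives no change at the digits printed from compound 2 to compound 4 (within the scatter), the first step in this set that changes only one place. At this position, then, the two halogen pairs cannot be told apart by this read-out, at least with the rest of the molecule kept as in compound 2. Nothing available here explains why the two pairs read alike.

The compounds shown leave open whether the same holds for groups other than these halogens, such as two methyl groups in place of the bromines or iodines. They also leave open what happens when a methoxy group replaces the hydroxy group on this ring.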